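The compounds below may be only part of what the source reports. "The series", "measured", "known", "first", "only" and "open" are said of these compounds alone.

Measured so far:
- compound 1, `COc1cc(OC)c2c(=O)cc(C(=O)Nc3ccc(Oc4cccnc4)cc3)[nH]c2c1`: 27700 nM
- compound 2, `COC(=O)c1cc(=O)c2cc(NC(=O)Nc3cc(F)cc(C(F)(F)F)c3)ccc2[nH]1`: > 20200 nM
- compound 3, `COC(=O)c1cc(=O)c2cc(NC(=O)Nc3cccc(C(C)=O)c3)ccc2[nH]1`: > 8080 nM

All three values come from a functional assay on UoC-B1 cells (Homo sapiens) for antiproliferative activity, with a stated time of 72 h; a lower number here means that less compound is needed, a higher number that more compound is needed for the effect. Compound 1 is the only one of the three with a definite number. For compound 2 the entry is a limit of this assay, not a number, as noted in the limit of > 20200 nM in this assay, at which 1 of the 3 values shown sits. For compound 3 the entry is likewise a limit, as noted in the limit of > 8080 nM in this assay, at which 1 of the 3 values shown sits, so where compound 3 truly stands is open; it is only known that it did not reach the effect within the range tested.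

Compound 4, `COC(=O)c1cc(=O)c2cc(NC(=O)Nc3ccc4c(c3)CCC4)ccc2[nH]1`, shares the core of compound 3 and differs from it in one place: 2,3-dihydro-1H-inden-5-yl in place of 3-acetylphenyl on an amide-type nitrogen. Among the compounds with values here, no measured pair in this set isolates such a change, so nothing here shows what size of step it should bring in this assay.

Because compound 3 gives only > 8080 nM, compound 4 is expected to sit in a similar region, with the step that the limit leaves unreadable from compound 3 to compound 4 estimated to be none beyond the scatter. The estimate for compound 4 in this assay is 10000 nM, within a range from 3000 nM to 40000 nM, with a real chance that the assay again reports only a limit.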

Compound 4, half-maximal effective concentration: > 24100 nM
Compound 4: no number, only a limit (the forecaster's own chance of this, stated with the estimate: 65%); middle value at least 2.4-fold (0.38 log units) away from the limit.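

In this assay, compound 3 and compound 4 each give only a limit, not a number, and the size of the step between them cannot be read. The compounds shown leave open whether 2,3-dihydro-1H-inden-5-yl in place of 3-acetylphenyl on an amide-type nitrogen changes the effect at all, and what concentration either compound would truly need.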